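From Fluoro to Methanesulfonamido on the Aromatic Ring

The source may hold more compounds than are shown below. What is called first, only, known or untested is meant among the compounds shown, and "the series" means these compounds.

In an ADME assay (liver) for metabolic stability, with Liver microsome (Rattus norvegicus) as the target, using microsomes and NADPH, with a stated time of 30 min, tested at 1 uM (on this read-out lower numbers stand for slow clearance and higher numbers for fast clearance), compound 3 (`Nc1ccc(S(=O)(=O)N2CCN(c3ncc(C(O)(C(F)(F)F)C(F)(F)F)cc3-c3cccc(F)c3)CC2)cn1`) gives 52 mL.min-1.g-1. Compound 2 (`Nc1ccc(S(=O)(=O)N2CCN(c3ncc(C(O)(C(F)(F)F)C(F)(F)F)cc3-c3ccoc3)CC2)cn1`) gives 57 mL.min-1.g-1, and the two stand level, with a 1.1-fold lower number from compound 2 to compound 3 (0.04 log units; within the scatter). Compound 1 (`CC(C)(O)C#Cc1cc(C(O)(C(F)(F)F)C(F)(F)F)cnc1N1CCN(S(=O)(=O)c2ccc(N)nc2)CC1`) gives 16 mL.min-1.g-1, which leaves compound 3 with compound 2 at the high end of the three numbers.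

Compound 4 (`CS(=O)(=O)Nc1cccc(-c2cc(C(O)(C(F)(F)F)C(F)(F)F)cnc2N2CCN(S(=O)(=O)c3ccc(N)nc3)CC2)c1`) carries methanesulfonamido in place of fluoro on an aromatic carbon, meta to a large group: methanesulfonamido in place of fluoro on an aromatic carbon. Among the compounds with values here, no measured step changes a group on this ring, so the evidence is indirect. The measured steps all concern the group that 3-fluorophenyl occupies on the shared core. Two of them are modest, a 3.6-fold higher number from compound 1 to compound 2 (0.55 log units; beyond the scatter) and a 3.3-fold higher number from compound 1 to compound 3 (0.51 log units; beyond the scatter), and both lead away from the 3-hydroxy-3-methylbut-1-yn-1-yl group of compound 1. The exchange of furan-3-yl for 3-fluorophenyl stayed within the scatter. These steps set the scale of what a change at this place has done, and none of them exceeds a modest size. A small move toward the lower numbers is expected, though the direction is uncertain. The expected change is a 1.6-fold lower number from compound 3 to compound 4 (0.20 log units; within the scatter), an estimate no larger in size than those modest steps. For compound 4 the estimated value is 33 mL.min-1.g-1, with an expected range of 14 mL.min-1.g-1 to 65 mL.min-1.g-1.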

Compound 4, intrinsic clearance in microsomes: 81 mL.min-1.g-1
The estimate for compound 4 lay 2.5-fold (0.39 log units) below the measured number; measured number above the stated range.
By their numbers in this assay, from the lowest: compound 1; then compounds 3, 2 and 4 (each within the scatter of the next).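

On the aromatic carbon meta to a large group, exchanging fluoro for methanesulfonamido brings in more heavy atoms, one hydrogen-bond donor and two hydrogen-bond acceptors, yet the read-out in this assay does not move beyond the scatter (a 1.6-fold higher number from compound 3 to compound 4 (0.19 log units; within the scatter)). Compound 4 also stands level with the furan-3-yl compound (a 1.4-fold higher number from compound 2 to compound 4 (0.15 log units; within the scatter)), so furan-3-yl, 3-fluorophenyl and 3-(methanesulfonamido)phenyl form one level group at this place on the shared core, and only the 3-hydroxy-3-methylbut-1-yn-1-yl group of compound 1 stands apart, now by a somewhat wider step (a 5.1-fold higher number from compound 1 to compound 4 (0.70 log units; beyond the scatter)). Nothing shown here offers a reason for these numbers.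

The compounds shown leave open whether an amine or a carboxylic acid in place of methanesulfonamido on this ring would stay level with compounds 2, 3 and 4. They also leave open whether the lower number of compound 1 belongs to its alkyne or to its hydroxyl, which a longer chain without the hydroxyl could separate.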